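The source may report more compounds than this note shows. Statements on the series, on what has been measured and on what is new or still open speak of the compounds shown alone.

Compound 3, `CN(Cc1ccccc1F)C(=O)C1CCN(C(=O)c2ccc(S(C)(=O)=O)c([N+](=O)[O-])c2)CC1`, stands at the edge of what the measurement can report. In an assay on isolated protein for inhibition of thyroid hormone receptor beta (Homo sapiens), read by fluorescence polarization (a higher number here means a weaker inhibitor, a lower number a stronger inhibitor), compound 3 gives > 60000 nM, which is a limit of the measurement rather than a number. Compound 1, `CC(C)N(C(=O)C1CCN(C(=O)c2ccc(S(C)(=O)=O)c([N+](=O)[O-])c2)CC1)C(C)C`, in this assay gives > 60000 nM, likewise a limit. Compound 2, `CN1CCN(C(=O)C2CCN(C(=O)c3ccc(S(C)(=O)=O)c([N+](=O)[O-])c3)CC2)CC1`, in this assay gives > 60000 nM, again a limit. Because (the limit of > 60000 nM in this assay, at which 3 of the 3 values shown sit), none of the three changes among the measured compounds can be sized: the step that the two limits leave unreadable from compound 1 to compound 2, the step that the two limits leave unreadable from compound 1 to compound 3 and the step that the two limits leave unreadable from compound 2 to compound 3 are all left unreadable by the two limits involved.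

Compound 4, `CC1Cc2ccccc2N1C(=O)C1CCN(C(=O)c2ccc(S(C)(=O)=O)c([N+](=O)[O-])c2)CC1`, differs from compound 3 by 2-methyl-2,3-dihydro-1H-indol-1-yl in place of (2-fluorobenzyl)(methyl)amino on a carbonyl carbon. Among the compounds with values here, no measured step bears on this change in a readable way, since every comparison available ends at the limit. The account therefore expects compound 4 to remain where compound 3 and its two relatives sit, with the step of a number no higher from compound 3 to compound 4 (the limit leaves the size open) expected to be nothing beyond the scatter. Compound 4 is estimated at 60000 nM, with a range from 20000 nM to 200000 nM, and most likely reported only as a limit.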

Compound 4, half-maximal inhibitory concentration: > 60000 nM
Compound 4 ended at the assay's limit; the forecaster's own chance of this, stated with the estimate: 80%; the middle value sits exactly at the limit.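

No step from compound 1, compound 2 or compound 3 to compound 4 can be read, for one reason shared by all three: the limit of > 60000 nM in this assay, at which 4 of the 4 values shown sit. The compounds shown leave open how strongly any of them inhibits the receptor in this assay, and whether changing the group on the carbonyl carbon makes any difference.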